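The source may hold more compounds than are shown below. What is called first, only, known or untested is meant among the compounds shown, and "the series" means these compounds.

Measured so far in an assay for binding affinity to Alpha-1A adrenergic receptor (Homo sapiens), read by radioligand binding; a higher number here means a weaker inhibitor, a lower number a stronger inhibitor:
Compound 1, `COc1ccc(S(C)(=O)=O)c(NCC2=NCCN2)c1`, gives 1620 nM.
Compound 2, `CSc1ccc(F)cc1NCC1=NCCN1`, gives 33.1 nM.
Compound 3, `COc1ccc(SC)c(NCC2=NCCN2)c1`, gives 174 nM.

Compound 3 stands second highest of the three numbers in this assay, with a 5.3-fold higher number from compound 2 to compound 3 (0.72 log units; beyond the scatter) and a 9.3-fold lower number from compound 1 to compound 3 (0.97 log units; beyond the scatter). Compound 4, `CSc1ccc(Cl)cc1NCC1=NCCN1`, differs from compound 3 in one place: chloro in place of methoxy on an aromatic carbon. Among the compounds with values here, the step that bears on this change is the one between compound 2 and compound 3, where methoxy in place of fluoro raised the number, and the new change removes that methoxy again in favour of a halogen. Compound 3 to compound 4 is therefore expected to move in the opposite direction, a 4.4-fold lower number from compound 3 to compound 4 (0.64 log units; beyond the scatter). Compound 4 is estimated at 40 nM in this assay, within 15 nM to 120 nM.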

Compound 4, inhibition constant: 18.6 nM
For compound 4 the middle estimate is 2.2-fold (0.33 log units) above the measured one; the measured number falls inside the stated range.
By their numbers in this assay, from the lowest: compounds 4 and 2 (each within the scatter of the next); then compound 3; then compound 1.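

In this assay, the chloro in place of methoxy change, para to the methylsulfanyl group, gives a 9.4-fold lower number from compound 3 to compound 4 (0.97 log units; beyond the scatter), so a second halogen at this position also ends well below the methoxy compound. The two halogens cannot be told apart here, with a 1.8-fold lower number from compound 2 to compound 4 (0.25 log units; within the scatter). No measurement shown explains this difference between methoxy and the halogens. The compounds shown leave open how an amine or a carboxylic acid would compare at this position. They also leave open whether the chloro in place of methoxy change would carry over with methylsulfonyl, the group found in compound 1.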